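Fluorine for chlorine on the outer ring of an aryloxy acid

The source may hold more compounds than are shown below. What is called first, only, known or untested is meant among the compounds shown, and "the series" means these compounds.

The measured compounds and their values:
Compound 1, `Cc1cc(Cl)ccc1-c1cc(COc2ccc([C@H](CC(=O)O)c3nccn3C)cc2)ccc1C`, 97 nM.
Compound 2, `Cc1c(Cl)cccc1-c1cccc(COc2ccc([C@H](CC(=O)O)c3nccn3C)cc2)c1`, 61 nM.
Compound 3, `Cc1cc(Cl)ccc1-c1cccc(COc2ccc([C@H](CC(=O)O)c3nccn3C)cc2)c1C`, 240 nM.

All three were tested in an assay on CHO cells for agonist activity at Free fatty acid receptor 1 (Homo sapiens), read by luminescence, with a stated time of 20 s, in the presence of a further agent that is not named here; on this read-out higher numbers stand for an effect only at larger amounts of compound and lower numbers for an effect already at smaller amounts. Compound 2 has the lowest number of the three; its gap to compound 1 lies within the scatter, so no order between those two can be claimed, while its gap to compound 3 lies beyond it. Compound 4, `Cc1ccc(F)cc1-c1cccc(COc2ccc([C@H](CC(=O)O)c3nccn3C)cc2)c1`, has not yet been measured. It differs from compound 2 in one place: 5-fluoro-2-methylphenyl in place of 3-chloro-2-methylphenyl on an aromatic carbon. Going by the values given here, no pair of measured compounds shows this kind of change, so nothing in the data tells how this assay answers to it. The closest hint is that compounds 1 and 3, which carry chlorine at another position of the outer ring together with a further methyl, give numbers that are the same as or higher than that of compound 2. A step from compound 2 to compound 4 of a 2.0-fold higher number from compound 2 to compound 4 (0.29 log units; within the scatter) is therefore expected, towards a somewhat higher number. For compound 4 the estimate is 120 nM, with a range from 45 nM to 320 nM.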

Compound 4, half-maximal effective concentration: 36 nM
Estimate against measurement, compound 4: 3.3-fold (0.52 log units) above; measured number outside the range, below it.
By their numbers in this assay, from the lowest: compounds 4, 2 and 1 (each within the scatter of the next, the first and the last beyond it); then compound 3.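

In this assay, replacing 3-chloro-2-methylphenyl with 5-fluoro-2-methylphenyl gives a 1.7-fold lower number from compound 2 to compound 4 (0.23 log units; within the scatter) and is the first single-place step shown on this outer ring. The chlorine can thus leave and a fluorine can enter elsewhere on the ring without the number moving beyond the scatter, so the two compounds cannot be ranked. Nothing at hand offers an explanation for this result.

Because compound 2 and compound 4 differ in both the halogen and its place on the ring, the compounds shown leave open what each of these changes does alone, which a 5-chloro-2-methylphenyl or a 3-fluoro-2-methylphenyl group would separate. Also open, going by these compounds, is how this assay would answer to a methoxy group, a nitrile or an amine on the same ring.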